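Adding a Second Chlorine to a Benzylated Purine Core

The compounds below may be only part of what the source reports. "The series", "measured", "known", "first", "only" and "open" are said of these compounds alone.

Compound 1 `ClCc1ccccc1Cn1cnc2c(Cl)nc(Cl)nc21`: 1020 nM
Compound 2 `ClCc1cccc(Cn2cnc3c(Cl)nc(Cl)nc32)c1`: 3090 nM
Compound 3 `ClCc1ccccc1Cn1cnc2ncnc(Cl)c21`: 4360 nM

Of the compounds shown here, three have been measured in a functional assay on U-251 cells (Homo sapiens) for cytotoxicity, read by sulforhodamine B assay, with a stated time of 48 h; on this read-out lower numbers stand for stronger inhibition of growth and higher numbers for weaker inhibition of growth. Compound 3 stands at the highest number of the three, though compound 2 sits within the usual scatter of it, while compound 1 lies clearly lower. Compound 4 `ClCc1ccccc1Cn1cnc2nc(Cl)nc(Cl)c21` has not been measured. It differs from compound 3 by chloro in place of hydrogen on an aromatic carbon. Within the data shown here, no measured pair shows this exact change on its own, so its size cannot be read off directly. Compound 1, which also carries a chloro group at this kind of position, gives 1020 nM, which points toward a lower number. For compound 4 a moderate step downward is expected, a 2.2-fold lower number from compound 3 to compound 4 (0.34 log units; beyond the scatter), possibly no larger than the scatter. Compound 4 is estimated at 2000 nM, within 700 nM to 6000 nM.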

Compound 4, concentration for total growth inhibition: 1170 nM
Beside the measured number, compound 4's estimate is 1.7-fold (0.23 log units) above it; the range from low to high includes it.
By their numbers in this assay, from the lowest: compounds 1 and 4 (each within the scatter of the next); then compounds 2 and 3 (each within the scatter of the next).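

In this assay, among these compounds, chloro in place of hydrogen on an aromatic carbon between two ring nitrogen atoms gives a 3.7-fold lower number from compound 3 to compound 4 (0.57 log units; beyond the scatter), the first direct reading of this change. The step lies beyond the usual scatter, so growth inhibition in these cells does respond to a change at this position. Nothing shown here explains why the chloro group has this effect.

As far as these compounds go, whether fluoro, an amine or a longer chain at this position would give a similar step remains open. So does whether the same change would give a similar step on another compound.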